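From 4-fluorobenzyl to 3-chlorobenzyl on the shared core

The source may hold more compounds than are shown below. What is called first, only, known or untested is meant among the compounds shown, and "the series" means these compounds.

In a functional assay on HepG2 cells (Homo sapiens) for antiproliferative activity, read by MTT assay, with a stated time of 48 h (on this read-out higher numbers stand for weaker inhibition and lower numbers for stronger inhibition), compound 1 `COc1ccc(-c2ccc3c(c2)C(=O)C(=O)N3C)cc1` gives 6670 nM and compound 2 `COc1ccc(-c2ccc3c(c2)C(=O)C(=O)N3Cc2ccc(F)cc2)cc1` gives 1120 nM as the lower of the two numbers. Within the data shown here, the only measured step (a 6.0-fold lower number from compound 1 to compound 2 (0.77 log units; beyond the scatter)) replaces hydrogen with 4-fluorophenyl and does not compare two substituted phenyl groups. Compound 3 `COc1ccc(-c2ccc3c(c2)C(=O)C(=O)N3Cc2cccc(Cl)c2)cc1` has 3-chlorophenyl in place of 4-fluorophenyl on a saturated chain carbon bound to an amide-type nitrogen in a ring. No shift beyond the scatter is therefore expected, and neither direction is favoured. The expected 1.1-fold higher number from compound 2 to compound 3 (0.03 log units; within the scatter) remains small. Compound 3 is estimated at 1200 nM with an expected range from 500 nM to 2900 nM in this read-out.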

Compound 3, half-maximal inhibitory concentration: 320 nM
For compound 3 the middle estimate is 3.8-fold (0.57 log units) above the measured one; the whole stated range lies above it.
By their numbers in this assay, from the lowest: compound 3; then compound 2; then compound 1.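

On a saturated chain carbon bound to an amide-type nitrogen in a ring, the choice of aryl group matters and not only its presence: 3-chlorophenyl in place of 4-fluorophenyl moves the number beyond the scatter (a 3.5-fold lower number from compound 2 to compound 3 (0.54 log units; beyond the scatter)). Against hydrogen, 3-chlorophenyl gives the largest step in the series (a 21-fold lower number from compound 1 to compound 3 (1.32 log units; beyond the scatter)), which exceeds that of 4-fluorophenyl (a 6.0-fold lower number from compound 1 to compound 2 (0.77 log units; beyond the scatter)). No measurement at hand accounts for this difference.

Open, from the compounds shown here alone, is whether chlorine or its placement carries the step: 3-fluorobenzyl and 4-chlorobenzyl would separate the two. Unsubstituted benzyl and a longer chain such as phenethyl at this place also remain open.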